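This account rests on a few compounds, and the source may have more. Where it says the series, first, only, none or still open, it means among the compounds named here.

In an ADME assay on MT4 cells (Homo sapiens) for cytotoxicity, read by MTT assay (a higher number here means that more compound is tolerated, a lower number that less compound is tolerated), compound 1 `Cc1ccc(-[n+]2noc([O-])c2CN2CCN(c3cccc(Cl)c3Cl)CC2)cc1` gives 31.7 ug/mL. Compound 2 `[O-]c1on[n+](-c2ccc(Cc3ccc(-[n+]4noc([O-])c4CN4CCN(c5cccc(Cl)c5Cl)CC4)cc3)cc2)c1CN1CCN(c2cccc(Cl)c2Cl)CC1` gives 20.8 ug/mL, within the scatter of compound 1, while compound 3 `[O-]c1on[n+](-c2ccc(Cc3ccc(-[n+]4noc([O-])c4CN4CCN(c5cccc(Cl)c5)CC4)cc3)cc2)c1CN1CCN(c2cccc(Cl)c2)CC1` gives 13.2 ug/mL, a lower number than compound 1 and beyond the scatter. Compound 4 `CC(=O)N1CCN(Cc2c([O-])on[n+]2-c2ccc(C)cc2)CC1` differs from compound 1 by one change: acetyl in place of 2,3-dichlorophenyl on an amine nitrogen in a ring. Among the compounds with values here, no measured pair shows this change, so the forecast rests on the structural change alone and remains uncertain. The expected shift is toward more compound tolerated, and it is estimated as a 2.5-fold higher number from compound 1 to compound 4 (0.40 log units; beyond the scatter). Compound 4 is expected to give about 80 ug/mL, with an estimated range from 30 ug/mL to 160 ug/mL.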

Compound 4, half-maximal cytotoxic concentration: 17.3 ug/mL
Estimate against measurement, compound 4: 4.6-fold (0.67 log units) above, and the stated range ends above it.
By their numbers in this assay, from the lowest: compounds 3, 4, 2 and 1 (each within the scatter of the next, the first and the last beyond it).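

In this assay, within the data shown here, the first step at this position is a 1.8-fold lower number from compound 1 to compound 4 (0.26 log units; within the scatter) with acetyl in place of 2,3-dichlorophenyl on the amine nitrogen in a ring. Among these compounds, the number thus stays within the scatter even when the aromatic ring on this nitrogen is gone, which the earlier compounds could not show. No available evidence bears on this result. The compounds shown leave open whether a benzyl group or a longer chain ending in a carboxylic acid on this nitrogen would move the number beyond the scatter.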